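Reshaping the Amine Side Chain of Compound 3

The compounds below may be only part of what the source reports. "The series", "measured", "known", "first", "only" and "open" are said of these compounds alone.

Measured in a functional assay on HL60/MX2 cells (Homo sapiens) for antiproliferative activity, read by MTT assay, with a stated time of 48 h; a lower number here means a stronger inhibitor, a higher number a weaker inhibitor:
- compound 1 `CN(C)CCCCn1c(N)c(-c2nc3ccccc3o2)c2nc(C#N)c(C#N)nc21`: 960 nM
- compound 2 `CN(C)CCCCn1c(N)c(-c2nc3ccccc3s2)c2nc(C#N)c(C#N)nc21`: 2140 nM
- compound 3 `CCN(CC)CCn1c(N)c(-c2nc3cc(Cl)ccc3[nH]2)c2nc(C#N)c(C#N)nc21`: 9290 nM

In this assay, compound 3 has the highest of the three numbers at 9290 nM. Compound 4 `CN(C)CCCCn1c(N)c(-c2nc3cc(Cl)ccc3[nH]2)c2nc(C#N)c(C#N)nc21` differs from it by 2-(dimethylamino)ethyl in place of diethylamino on a saturated chain carbon, two bonds along the chain from an aromatic nitrogen, with 2-(dimethylamino)ethyl in place of diethylamino on a saturated chain carbon, two bonds along the chain from an aromatic nitrogen. For the measured compounds named here, the only measured step, a 2.2-fold higher number from compound 1 to compound 2 (0.35 log units; beyond the scatter), concerns another group and is modest, so no measured step isolates this change. Compound 1 at 960 nM and compound 2 at 2140 nM carry the chain of compound 4, but they also differ from it elsewhere. A moderately lower number is therefore expected, with the expected step being a 2.7-fold lower number from compound 3 to compound 4 (0.42 log units; beyond the scatter). For compound 4 the estimated value is 3500 nM, with an expected range of 1200 nM to 9500 nM.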

Compound 4, half-maximal inhibitory concentration: 580 nM
Beside the measured number, compound 4's estimate is 6.0-fold (0.78 log units) above it; measured number outside the range, below it.
By their numbers in this assay, from the lowest: compounds 4 and 1 (each within the scatter of the next); then compound 2; then compound 3.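

In this assay, for the compounds shown here, the 4-(dimethylamino)butyl chain in place of 2-(diethylamino)ethyl gives the first measured step at this position, and it is large (a 16-fold lower number from compound 3 to compound 4 (1.20 log units; beyond the scatter)). With that chain held fixed, 5-chloro-1H-benzimidazol-2-yl in place of 1,3-benzothiazol-2-yl gives a smaller, modest step (a 3.7-fold lower number from compound 2 to compound 4 (0.57 log units; beyond the scatter)), while in place of 1,3-benzoxazol-2-yl it gives a step within the scatter (a 1.7-fold lower number from compound 1 to compound 4 (0.22 log units; within the scatter)). Nothing available explains the size of the chain step. On these data alone, whether that step follows the chain length or the amine end stays open, since the two change together. A 4-(diethylamino)butyl chain or a piperidine at the chain end would separate these readings.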